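The source may hold more compounds than are shown below. What is called first, only, known or untested is meant among the compounds shown, and "the series" means these compounds.

Measured in a functional assay on MCF7 cells (Homo sapiens) for cytotoxicity, read by MTT assay, with a stated time of 24 h; a lower number here means a stronger inhibitor, a higher number a weaker inhibitor:

- Compound 1 `O=C1/C(=C/c2ccccc2F)CN(Cc2cn(Cc3ccccc3F)nn2)C/C1=C\c1ccccc1F`: 6000 nM
- Compound 2 `COc1ccc(/C=C2\CN(C(=S)SCc3cn(Cc4ccc(F)cc4)nn3)C/C(=C\c3ccc(OC)cc3)C2=O)cc1`: > 100000 nM (a limit of the assay)
- Compound 3 `O=C1/C(=C/c2ccccc2F)CN(C(=S)SCc2cn(Cc3ccccc3F)nn2)C/C1=C\c1ccccc1F`: 51600 nM

Of the two actual numbers, compound 1 has the lower one at 6000 nM. Compound 3 stands higher at 51600 nM, a gap beyond the scatter. Compound 2 gives > 100000 nM, which is a limit and not a number.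

Compound 4 `O=C1/C(=C/c2ccccc2F)CN(Cc2cn(Cc3ccc(F)cc3)nn2)C/C1=C\c1ccccc1F` has not yet been measured. It keeps the core of compound 1, with 4-fluorophenyl in place of 2-fluorophenyl on a saturated chain carbon bound to an aromatic nitrogen. Among the compounds with values here, no pair of measured compounds shows this change, so the expectation rests only on compound 1 at 6000 nM and on the closeness of the two structures.

In this assay, a small expected rise in the number, a 1.2-fold higher number from compound 1 to compound 4 (0.07 log units; within the scatter), is not anticipated to clear the scatter. For compound 4 the estimated value is 7000 nM, with an expected range of 2500 nM to 20000 nM.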

Compound 4, half-maximal inhibitory concentration: 6000 nM
Beside the measured number, compound 4's estimate is 1.2-fold (0.07 log units) above it; low and high end bracket the measured number.
By their numbers in this assay, from the lowest: compounds 1 and 4 (each within the scatter of the next); then compound 3. At a limit, above all of these: compound 2.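

In this assay, within the data shown here, 4-fluorophenyl in place of 2-fluorophenyl on a saturated chain carbon bound to an aromatic nitrogen gives no change at the digits printed from compound 1 to compound 4 (within the scatter), the first direct reading at this position, since no earlier pair differed in one place. With the core of compound 1 kept, the two fluorophenyl groups cannot be told apart in this assay. The data shown give no reason for this outcome.

On these data alone, only these two fluorophenyl groups appear at this position, so it remains open whether 3-fluorophenyl, unsubstituted phenyl or a longer chain such as 2-phenylethyl would give a similar value. As far as these compounds go, it is also open whether the same change would leave the value of compound 3 similarly unmoved, since that compound carries a different link to the shared core.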